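Carbonyl aryl variation and a hydroxy for fluoro swap

The compounds below may be only part of what the source reports. "The series", "measured", "known", "first", "only" and "open" are said of these compounds alone.

Three compounds on a shared core are measured in a functional assay on HCT-116 cells (Homo sapiens) for cytotoxicity, read by MTT assay, with a stated time of 48 h; on this read-out lower numbers stand for stronger inhibition and higher numbers for weaker inhibition. Compound 1 `O=C(/C=C/c1ccc2c(c1)B(O)OC2)c1ccco1` carries furan-2-yl on the carbonyl carbon and gives 24100 nM. Compound 2 `Cn1cccc1C(=O)/C=C/c1ccc2c(c1)B(O)OC2` carries 1-methyl-1H-pyrrol-2-yl on the carbonyl carbon; for compound 2 the assay reports only a limit, > 100000 nM, and the limit of > 100000 nM in this assay, at which 1 of the 3 values shown sits, marks that one of the three values sits there. Compound 3 `O=C(/C=C/c1ccc2c(c1)B(O)OC2)c1cccc(F)c1` carries 3-fluorophenyl on the carbonyl carbon and gives 6700 nM, the lowest of the two numbers shown, the nearest being compound 1. The measured steps are an at least 4.1-fold higher number from compound 1 to compound 2 (0.61 log units; beyond the scatter), a 3.6-fold lower number from compound 1 to compound 3 (0.56 log units; beyond the scatter) and an at least 14-fold lower number from compound 2 to compound 3 (1.17 log units; beyond the scatter); each of them exchanges the whole ring on the carbonyl carbon.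

Compound 4 `O=C(/C=C/c1ccc2c(c1)B(O)OC2)c1cccc(O)c1` is not yet measured. It differs from compound 3 by hydroxy in place of fluoro on an aromatic carbon. Going by the values given here, none of the measured steps touches a substituent on a ring that is kept; all three replace the ring itself, so they give no direct reading for this change. With the phenyl ring retained, only a small step is expected, a 1.2-fold higher number from compound 3 to compound 4 (0.08 log units; within the scatter), within or near the scatter, in no firm direction. Compound 4 is therefore estimated at 8000 nM, with a range from 3000 nM to 25000 nM.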

Compound 4, half-maximal inhibitory concentration: 6500 nM
Compound 4: the middle estimate sits 1.2-fold (0.09 log units) above what was measured, and the stated range covers the measured number.
By their numbers in this assay, from the lowest: compounds 4 and 3 (each within the scatter of the next); then compound 1. At a limit, above all of these: compound 2.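

Going by these compounds alone, the step from fluoro to hydroxy on an aromatic carbon, meta to a large group, is the first reading of a substituent change on a retained ring: a 1.0-fold lower number from compound 3 to compound 4 (0.01 log units; within the scatter), so in this assay the two groups cannot be told apart at this place, although their counts of hydrogen-bond donors and acceptors differ. The gap to the other carbonyl rings therefore appears with hydroxy as it does with fluoro: exchanging furan-2-yl for 3-hydroxyphenyl gives a 3.7-fold lower number from compound 1 to compound 4 (0.57 log units; beyond the scatter), and exchanging 1-methyl-1H-pyrrol-2-yl for 3-hydroxyphenyl gives an at least 15-fold lower number from compound 2 to compound 4 (1.18 log units; beyond the scatter). The value of compound 2 is a limit and not a number: the limit of > 100000 nM in this assay, at which 1 of the 4 values shown sits.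

Going by these compounds, two groups at one place cannot show how far this tolerance extends, and it remains open whether an amine, a methoxy group or a carboxylic acid at the same place would also read level with fluoro and hydroxy. Also open, on these data alone, is whether fluoro and hydroxy would read alike on another carbon of the phenyl ring.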